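The source may hold more compounds than are shown below. What is called first, only, known or untested is meant among the compounds shown, and "the series" means these compounds.

Measured in a functional assay on COLO 205 cells (Homo sapiens) for inhibition, read by sulforhodamine B assay; a higher number here means a weaker inhibitor of growth, a lower number a stronger inhibitor of growth:
- compound 1 `COc1cc(-c2ccc(-c3ccc(-c4nc5cc(C)ccc5[nH]4)cc3)cc2)cc(OC)c1OC`: 190 nM
- compound 2 `Fc1ccc(-c2ccc(-c3ccc(-c4nc5ccccc5[nH]4)cc3)cc2)cc1`: 100000 nM
- compound 3 `Oc1cccc2[nH]c(-c3ccc(-c4ccc(-c5ccc(F)cc5)cc4)cc3)nc12`: 1220 nM

Among these three, compound 3 holds the middle place, with 1220 nM. Compound 1 has a lower number and compound 2 a higher one. The next compound, compound 4 `COc1ccc(-c2ccc(-c3ccc(-c4nc5c(O)cccc5[nH]4)cc3)cc2)cc1OC`, carries 3,4-dimethoxyphenyl in place of 4-fluorophenyl on an aromatic carbon. Among the compounds with values here, the only measured step, an 82-fold lower number from compound 2 to compound 3 (1.91 log units; beyond the scatter), is large, but it comes from hydroxy in place of hydrogen on an aromatic carbon. Within the data shown here, compound 4 keeps that hydroxy, so this step does not measure the new change, and no measured step isolates it. Among the measured compounds shown here, the nearest guide is compound 1, the only measured compound with methoxy groups, at 190 nM, although it also differs from compound 3 elsewhere. A moderately lower number is therefore expected, with wide uncertainty. The estimated change is a 2.4-fold lower number from compound 3 to compound 4 (0.39 log units; beyond the scatter). Compound 4 is expected at 500 nM, within an estimated range of 130 nM to 2500 nM.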

Compound 4, concentration for 50% growth inhibition: 1320 nM
Compound 4: middle estimate off by 2.6-fold (0.42 log units), on the low side, within the range that was stated.
By their numbers in this assay, from the lowest: compound 1; then compounds 3 and 4 (each within the scatter of the next); then compound 2.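

In this assay, 3,4-dimethoxyphenyl in place of 4-fluorophenyl on an aromatic carbon para to a large group gives a 1.1-fold higher number from compound 3 to compound 4 (0.03 log units; within the scatter). Within the data shown here, the earlier compounds offered no step at this position: the only one, an 82-fold lower number from compound 2 to compound 3 (1.91 log units; beyond the scatter), came from hydroxy in place of hydrogen, so this is the first reading of a change here, and with the hydroxy kept, the exchange of these two groups leaves the number within the scatter. Nothing measured on these compounds bears on why the two groups read alike.

From the compounds shown here alone, it remains open whether the same exchange would read alike on a core without the hydroxy, so the two changes cannot yet be taken as independent. Going by these compounds, it is also open how a carboxylic acid or an amine at this position would read, since both groups compared here are substituted phenyl rings.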